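This account rests on a few compounds, and the source may have more. Where it says the series, first, only, none or still open, it means among the compounds named here.

Compound 3 `COC(=O)c1ccc(NCc2cncn2Cc2cccc([N+](=O)[O-])c2)cc1-c1ccccc1` was examined in a toxicity assay on NIH3T3 cells (Mus musculus) for cytotoxicity, read by resazurin assay; a lower number here means that less compound is needed, a higher number that more compound is needed for the effect. In this assay compound 3 gives > 10000 nM, which is a limit of the assay and not a number. Compound 1 `COC(=O)c1ccc(NCc2cncn2Cc2ccc(N)cc2)cc1-c1ccccc1` was measured alongside it. In this assay compound 1 gives > 10000 nM, also a limit. Compound 2 `COC(=O)c1ccc(NCc2cncn2Cc2cccc(C#N)c2)cc1-c1ccccc1` completes the set. In this assay compound 2 gives > 10000 nM, again a limit. The steps a step that the two limits leave unreadable from compound 1 to compound 2, a step that the two limits leave unreadable from compound 1 to compound 3 and a step that the two limits leave unreadable from compound 2 to compound 3 therefore cannot be sized because of the limit of > 10000 nM in this assay, at which 3 of the 3 values shown sit. Compound 4 `COC(=O)c1ccc(NCc2cncn2Cc2ccccc2[N+](=O)[O-])cc1-c1ccccc1` is not yet measured. The change made is 2-nitrophenyl in place of 3-nitrophenyl on a saturated chain carbon bound to an aromatic nitrogen. Among the compounds with values here, no measured step gives a readable size that bears on it. Compound 4 is expected to remain at the limit, with a step of a number no higher from compound 3 to compound 4 (the limit leaves the size open) expected near zero. The estimate for compound 4 in this assay is 10000 nM, between 4000 nM and 30000 nM.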

Compound 4, half-maximal effective concentration: 10000 nM
The estimate for compound 4 equals the measured number at the digits printed, within the range that was stated.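

Within the data shown here, with 2-nitrophenyl in place of 3-nitrophenyl, this assay gives a real number for the first compound in this set: compound 4 gives 10000 nM. Compound 3 gives > 10000 nM, which is a limit of the assay and not a number. The steps are a number no higher from compound 3 to compound 4 (the limit leaves the size open) and a number no higher from compound 2 to compound 4 (the limit leaves the size open) and a number no higher from compound 1 to compound 4 (the limit leaves the size open) and therefore cannot be read, because the other values all sit at that limit: the limit of > 10000 nM in this assay, at which 3 of the 4 values shown sit.

On these data alone, whether moving the nitro group changes cytotoxicity at all remains open. Also open, as far as these compounds go, is how this assay responds to a carboxylic acid or a longer chain in place of the 2-nitrophenyl group.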